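Swapping the carbamate of compound 3 for a trifluoromethyl benzoate

The compounds below may be only part of what the source reports. "The series", "measured", "known", "first", "only" and "open" are said of these compounds alone.

Of the compounds shown here, three of one shared core have been tested in a functional assay on MCF7 cells (Homo sapiens) for antiproliferative activity, read by MTT assay, with a stated time of 72 h; a higher number here means a weaker inhibitor, a lower number a stronger inhibitor. Compound 1 `CC1=CCC2C(CC[C@@]2(C)O)C(C)(C)C1CC[C@@H]1[C@@]2(C)CC[C@@H](O)C(C)(C)O[C@@H]2CC[C@]1(C)O` gives 44500 nM. Compound 2 `CC1=CC[C@H]2[C@@H]1CC=C(C)[C@@H](CC[C@H]1[C@]3(C)CC[C@H](OC(=O)c4ccccc4)C(C)(C)O[C@H]3CC[C@@]1(C)O)C2(C)C` gives 23100 nM. Compound 3 `CC1=CC[C@H]2[C@H](CC[C@]2(C)O)C(C)(C)[C@@H]1CC[C@H]1[C@]2(C)CC[C@H](OC(=O)NS(=O)(=O)c3ccc(C)cc3)C(C)(C)O[C@H]2CC[C@@]1(C)O` gives only a limit, > 50000 nM, which is the edge of what this assay can report rather than a number. That limit is where compound 3 stands, as noted in the limit of > 50000 nM in this assay, at which 1 of the 3 values shown sits, so nothing can be said about how far beyond it the true value lies.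

Compound 4 `CC1=CC[C@H]2[C@H](CC[C@]2(C)O)C(C)(C)[C@@H]1CC[C@H]1[C@]2(C)CC[C@H](OC(=O)c3ccccc3C(F)(F)F)C(C)(C)O[C@H]2CC[C@@]1(C)O` is the next step. It differs from compound 3 in one place: 2-(trifluoromethyl)phenyl in place of ((4-methylphenyl)sulfonyl)amino on a carbonyl carbon.

Within the data shown here, no measured pair in this set differs in only one place, so the size of this step can only be guessed. Compound 4 is expected to give 30000 nM, with a likely range from 12000 nM to 60000 nM, because compound 2 gives 23100 nM. The expected step from an at least 1.6-fold lower number from compound 3 to compound 4 (0.22 log units; that floor lies within the scatter) is towards a stronger inhibitor, but it may also fall within the scatter or stay at the limit.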

Compound 4, half-maximal inhibitory concentration: 19200 nM
For compound 4 the middle estimate is 1.6-fold (0.19 log units) above the measured one, within the range that was stated.
By their numbers in this assay, from the lowest: compounds 4, 2 and 1 (each within the scatter of the next, the first and the last beyond it). At a limit, above all of these: compound 3.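

In this assay, putting 2-(trifluoromethyl)phenyl on the carbonyl carbon in place of ((4-methylphenyl)sulfonyl)amino gives an at least 2.6-fold lower number from compound 3 to compound 4 (0.41 log units; beyond the scatter). Among these compounds, this is the first single change in the set that can be read, and it shows that what sits at this place can move the number beyond the scatter, towards a stronger inhibitor. The step is only a floor and its full size stays unknown, because compound 3 stands at a limit: the limit of > 50000 nM in this assay, at which 1 of the 4 values shown sits.

The compounds shown do not separate what the trifluoromethyl group contributes from what the aromatic ring contributes in this swap. Also open, going by these compounds, is how a longer carbon chain, or a phenyl ring carrying an amine or a carboxylic acid, would behave at this place.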